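A few compounds are considered here, and "the series" means these few. Any claim that something is new, unique, unknown or untested is made for them only; others in the source may bear on it.

Working notes on the series. Among the compounds with values here, in a functional assay on KB cells (Homo sapiens) for cytotoxicity, read by MTT assay, with a stated time of 72 h (a lower number here means a stronger inhibitor, a higher number a weaker inhibitor), compound 2 `O=c1c2ncn(-c3ccccc3)c2nc(N2CCCCC2)n1-c1ccc(Cl)cc1` gives 72800 nM, the highest of the two numbers recorded so far, with no compound weaker than it in hand. The nearest neighbour, compound 1 `CCCCN(CCCC)c1nc2c(ncn2-c2ccccc2)c(=O)n1-c1ccccc1`, gives 9500 nM in this assay, a lower number that lies beyond the scatter of the measurement. Within the data shown here, compound 1 and compound 2 differ in more than one place, so their two values are reported as they stand and no single step is isolated from them. Compound 3 `CCCCNc1nc2c(ncn2-c2ccccc2)c(=O)n1-c1ccc(Cl)cc1` has not yet been measured in this assay. It differs from compound 2 in one place: butylamino in place of piperidin-1-yl on an aromatic carbon. Among the measured compounds shown here, no measured pair isolates this exchange, so its effect is not known from the data. The step from compound 2 to compound 3 is expected to be a modest fall in the number, a 2.4-fold lower number from compound 2 to compound 3 (0.39 log units; beyond the scatter), though a step within the scatter cannot be ruled out. Compound 3 is therefore estimated at 30000 nM in this assay, within a range from 8000 nM to 100000 nM.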

Compound 3, half-maximal inhibitory concentration: 37700 nM
Beside the measured number, compound 3's estimate is 1.3-fold (0.10 log units) below it; the measured number falls inside the stated range.
By their numbers in this assay, from the lowest: compound 1; then compounds 3 and 2 (each within the scatter of the next).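

In this assay, within the data shown here, butylamino in place of piperidin-1-yl on the aromatic carbon between two ring nitrogen atoms gives a 1.9-fold lower number from compound 2 to compound 3 (0.29 log units; within the scatter), the first step at this position that isolates a single place. At this carbon, an open chain with one hydrogen-bond donor and a six-membered non-aromatic ring with none therefore give values within the scatter of each other, and this single exchange cannot separate the loss of the ring from the gain of the donor. No measurement available here bears on this result.

As far as these compounds go, compound 1, at 9500 nM, differs from compound 2 and compound 3 in more than one place, so what sets its value apart stays open. From the compounds shown here alone, whether a free amino group or a morpholin-4-yl ring at this carbon would give a similar value also remains open.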